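Lengthening the Ester Chain Further: Expected Cytotoxicity

This account rests on a few compounds, and the source may have more. Where it says the series, first, only, none or still open, it means among the compounds named here.

In a functional assay on A549 cells (Homo sapiens) for cytotoxicity, read by MTT assay, with a stated time of 24 h, tested at 10 uM (on this read-out lower numbers stand for a stronger effect and higher numbers for a weaker effect at the one concentration tested), compound 2 `CCCCCCCCCCCCCCCOC(=O)CCC(=O)N1CCN(CCCOc2cc3c(Nc4ccc(F)c(Cl)c4)ncnc3cc2OC)CC1` gives 92%. Within the data shown here, the only other number comes from compound 1 `CCCCCCCCCOC(=O)CCC(=O)N1CCN(CCCOc2cc3c(Nc4ccc(F)c(Cl)c4)ncnc3cc2OC)CC1`, which gives 90%, and the two lie within the scatter of each other. The step of a number 2 percentage points higher from compound 1 to compound 2 (within the scatter) shows that adding a hexyl group to this saturated chain changed nothing beyond the scatter. Compound 3 `CCCCCCCCCCCCCCCCCCCOC(=O)CCC(=O)N1CCN(CCCOc2cc3c(Nc4ccc(F)c(Cl)c4)ncnc3cc2OC)CC1` carries the change (butyl in place of hydrogen on a saturated chain carbon, ten or more bonds along the chain from an oxygen next to a carbonyl group). Among the measured compounds shown here, because the one comparable step was a number 2 percentage points higher from compound 1 to compound 2 (within the scatter), no shift beyond the scatter is expected in this assay, and the expected step is no change at the digits printed from compound 2 to compound 3 (within the scatter). Compound 3 is therefore estimated at 92%, with a range from 82% to 100%.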

Compound 3, a percentage reported as activity, at one concentration (the size of the read-out at that concentration, not a potency): 94.5%
For compound 3 the middle estimate is 2.5 percentage points below the measured one; the measured number falls inside the stated range.
By their numbers in this assay, from the lowest: compounds 1, 2 and 3 (each within the scatter of the next).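

In this assay, the butyl change at this far point on the chain gives a number 2.5 percentage points higher from compound 2 to compound 3 (within the scatter) and so adds a second step that stays within the scatter. The whole decyl change gives a number 4.5 percentage points higher from compound 1 to compound 3 (within the scatter) and shows that even this much larger addition, read as a single step, does not leave the scatter. No measurement here offers an explanation for this result. Still open, from the compounds shown here alone, is whether a shorter chain, or an amine or a carboxylic acid at the chain end, would give a lower number at this one concentration.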